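The source may report more compounds than this note shows. Statements on the series, on what has been measured and on what is new or still open speak of the compounds shown alone.

Measured compounds:
Compound 1 `Cc1nc(N)sc1CCCN/C(N)=N/C(=O)NC(C)c1ccc(Br)cc1`: 30.2 nM
Compound 2 `Cc1nc(N)sc1CCCN/C(N)=N/C(=O)NC(C)c1ccc(OC(F)(F)F)cc1`: 126 nM

In an assay on membranes from Sf9 cells for displacement of a labelled ligand from histamine H2 receptor (Homo sapiens), read by scintillation counting, with a stated time of 60 min (on this read-out lower numbers stand for stronger inhibition and higher numbers for weaker inhibition), compound 1 gives 30.2 nM, the lowest of the two numbers; compound 2 gives 126 nM, and the step of a 4.2-fold higher number from compound 1 to compound 2 (0.62 log units; beyond the scatter) shows that even a change of one group on the ring costs something. Compound 3 `Cc1nc(N)sc1CCCN/C(N)=N/C(=O)NC(C)c1cccs1` is not yet measured; it differs from compound 1 by thiophen-2-yl in place of 4-bromophenyl on a saturated chain carbon bound to an amide-type nitrogen and a saturated chain carbon. Among the measured compounds shown here, this change replaces the whole ring rather than one group, and only the step from compound 1 to compound 2 bears on it, so a modest weakening in this assay is expected. Compound 3 is therefore estimated at 80 nM (range 25 nM to 250 nM), an expected step of a 2.6-fold higher number from compound 1 to compound 3 (0.42 log units; beyond the scatter).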

Compound 3, inhibition constant: 63.1 nM
Compound 3: middle estimate off by 1.3-fold (0.10 log units), on the high side; measured number inside the range.
By their numbers in this assay, from the lowest: compound 1; then compounds 3 and 2 (each within the scatter of the next).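

In this assay, replacing the whole 4-bromophenyl ring with thiophen-2-yl gives a 2.1-fold higher number from compound 1 to compound 3 (0.32 log units; beyond the scatter). Among the compounds shown here, the earlier compounds changed only one group on the ring, whereas this result shows that a smaller, five-membered aromatic ring containing sulfur and no bromine is accepted at this place with only a modest loss. Nothing measured here explains the loss. From the compounds shown here alone, it remains open how a phenyl ring without a bromo group, a pyridyl ring or a saturated cyclohexyl ring would fare at this place.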